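Removing the aryl chain from the pyrrolidine nitrogen substituent

The source may hold more compounds than are shown below. What is called first, only, known or untested is meant among the compounds shown, and "the series" means these compounds.

Of the compounds shown here, two sharing one core have been measured. Compound 1 `COc1ccc(CN2CCC[C@H]2COC(c2ccccc2)c2ccc(Cl)cc2)cc1` gives 30000 nM in a functional assay on MDA-MB-361 cells (Homo sapiens) for inhibition (a lower number here means a stronger inhibitor, a higher number a weaker inhibitor), and compound 2 `COc1ccc(CCCN2CCC[C@H]2COC(c2ccccc2)c2ccc(Cl)cc2)cc1` gives 11000 nM in this assay. Within the data shown here, compound 2 stands with the lowest of the two numbers; the only step measured so far is a 2.7-fold lower number from compound 1 to compound 2 (0.44 log units; beyond the scatter), a modest gain on lengthening the chain. Compound 3 `CN1CCC[C@H]1COC(c1ccccc1)c1ccc(Cl)cc1` differs from compound 2 by hydrogen in place of 2-(4-methoxyphenyl)ethyl on a saturated chain carbon bound to an amine nitrogen in a ring, so the whole aromatic part of that substituent is gone and a methyl remains on the ring nitrogen. Among the measured compounds shown here, no measured step shows such a removal; the one step from compound 1 to compound 2 only shows that the aryl group with a longer link helped a little. Compound 3 is therefore expected to give a weaker result in this assay, with the step of a 3.6-fold higher number from compound 2 to compound 3 (0.56 log units; beyond the scatter) estimated, and the value of compound 3 is estimated at 40000 nM within a range of 12000 nM to 130000 nM.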

Compound 3, half-maximal inhibitory concentration: 47000 nM
Estimate against measurement, compound 3: 1.2-fold (0.07 log units) below; the range from low to high includes it.
By their numbers in this assay, from the lowest: compound 2; then compounds 1 and 3 (each within the scatter of the next).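

In this assay, hydrogen in place of 2-(4-methoxyphenyl)ethyl on a saturated chain carbon bound to an amine nitrogen in a ring gives a modest loss (a 4.3-fold higher number from compound 2 to compound 3 (0.63 log units; beyond the scatter)), so this position does respond to its substituent once the aromatic ring sits on the longer chain. The shorter substituent shows no such effect (a 1.6-fold higher number from compound 1 to compound 3 (0.19 log units; within the scatter)): with hydrogen in place of 4-methoxyphenyl, compound 1 and compound 3 cannot be told apart, and among these three only compound 2 stands out. Nothing available accounts for this difference between the two chain lengths.

From the compounds shown here alone, whether a chain longer than that of compound 2 would lower the number further remains open. So does whether the methoxy group itself matters, or whether an amine or a carboxylic acid on the aromatic ring could take its place.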